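Swapping a ring for a chain on the aryl core

The compounds below may be only part of what the source reports. "The series", "measured", "known", "first", "only" and "open" are said of these compounds alone.

Of the compounds shown here, three have been measured in an assay on cells for antagonist activity at transient receptor potential cation channel subfamily V member 1 (Homo sapiens), read by FLIPR and calcium flux, with a stated time of 6 min; on this read-out higher numbers stand for weaker inhibition and lower numbers for stronger inhibition. Compound 1 `CCCOc1nc(C(C)(C)C)ccc1CNC(=O)C(C)c1ccc(NS(C)(=O)=O)c(F)c1` gives 1.7 nM. Compound 2 `CC(C(=O)NCc1ccc(C(C)(C)C)cc1N1CCCC1)c1ccc(NS(C)(=O)=O)c(F)c1` gives 8.1 nM. Compound 3 `CC1CCN(c2cc(C(C)(C)C)ccc2CNC(=O)C(C)c2ccc(NS(C)(=O)=O)c(F)c2)CC1` gives 0.7 nM, the lowest of the three numbers; the distance from compound 1 is beyond the scatter, and the change a 12-fold lower number from compound 2 to compound 3 (1.06 log units; beyond the scatter) is large. Compound 4 `CCCOc1cc(C(C)(C)C)ccc1CNC(=O)C(C)c1ccc(NS(C)(=O)=O)c(F)c1` has not yet been measured. The difference from compound 3 is propoxy in place of 4-methylpiperidin-1-yl on an aromatic carbon. For the measured compounds named here, no measured step covers exactly this change on the same core. Compound 1 carries the same propoxy group on a different core, and its value of 1.7 nM sits within the same potent range as compound 3, so a modest shift is all that is expected. The expected step is a 2.9-fold higher number from compound 3 to compound 4 (0.46 log units; beyond the scatter), a small weakening that may well fall within the scatter. Compound 4 is therefore estimated at 2 nM, with a likely range from 0.7 nM to 6 nM in this assay.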

Compound 4, inhibition constant: 4.4 nM
Compound 4: middle estimate off by 2.2-fold (0.34 log units), on the low side; low and high end bracket the measured number.
By their numbers in this assay, from the lowest: compound 3; then compound 1; then compounds 4 and 2 (each within the scatter of the next).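

At this position, ortho to a large group and meta to a tert-butyl group, having a ring is not enough on its own to set the number in this assay. Propoxy in place of 4-methylpiperidin-1-yl gives a 6.3-fold higher number from compound 3 to compound 4 (0.80 log units; beyond the scatter) and falls short of that ring, whereas propoxy in place of pyrrolidin-1-yl gives a 1.8-fold lower number from compound 2 to compound 4 (0.27 log units; within the scatter) and cannot be told apart from that smaller ring. For the compounds shown here, the earlier step compared only one ring with another, so this open chain adds a new reference point, though no measurement here explains the result.

A plain piperidin-1-yl ring would help show whether ring size or the extra methyl group on compound 3 matters more. On these data alone, how a butoxy or ethoxy chain would compare with propoxy on this core remains open.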